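Swapping Methyl for Fluoro on the Carboxyphenyl Ring

This account rests on a few compounds, and the source may have more. Where it says the series, first, only, none or still open, it means among the compounds named here.

Within the data shown here, compound 2 `Cc1cc(C(=O)O)ccc1OC[C@H](C)COc1ccc(C(=O)CC(C)(C)C)c(O)c1C` is one of two compounds measured in an assay for positive allosteric modulation of metabotropic glutamate receptor 2 (Rattus norvegicus) (a higher number here means that more compound is needed for the effect, a lower number that less compound is needed), and in that assay compound 2 gives 446 nM, the higher of the two numbers. Among the measured compounds shown here, its neighbour compound 1 `Cc1c(OC[C@@H](C)COc2ccc(F)c(C(=O)O)c2)ccc(C(=O)CC(C)(C)C)c1O` gives 112 nM in this assay, and the only measured step, a 4.0-fold higher number from compound 1 to compound 2 (0.60 log units; beyond the scatter), arises from exchanging one carboxyphenyl group for another on an oxygen on a saturated carbon. Compound 3 `Cc1c(OC[C@@H](C)COc2ccc(C(=O)O)cc2F)ccc(C(=O)CC(C)(C)C)c1O` has not yet been measured; it differs from compound 2 by fluoro in place of methyl on an aromatic carbon. For the measured compounds named here, no measured step exchanges methyl for fluoro, so the single step available shows only that rearranging substituents on this ring shifts the number by a modest amount. Compound 3 is therefore expected to land at 300 nM, within 90 nM to 1000 nM, a change of a 1.5-fold lower number from compound 2 to compound 3 (0.17 log units; within the scatter) that is estimated to be small and of uncertain direction.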

Compound 3, half-maximal effective concentration: 222 nM
The estimate for compound 3 lay 1.4-fold (0.13 log units) above the measured number; the measured number falls inside the stated range.
By their numbers in this assay, from the lowest: compounds 1, 3 and 2 (each within the scatter of the next, the first and the last beyond it).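

Among these compounds, compound 3 gives the first direct reading at this position, on an aromatic carbon ortho to a large group and meta to a carboxy group. In this assay the exchange of methyl for fluoro gives a 2.0-fold lower number from compound 2 to compound 3 (0.30 log units; within the scatter) and so does not separate the two groups. The step of a 2.0-fold higher number from compound 1 to compound 3 (0.30 log units; within the scatter) likewise does not separate the 4-carboxy-2-fluorophenyl group from the 3-carboxy-4-fluorophenyl group, even though compound 1 and compound 2 stand apart beyond the scatter, and no evidence is available that explains these numbers.

Compound 2 and compound 3 hold only methyl and fluoro at this place, which leaves open how a chloro group, a methoxy group or a plain hydrogen would read there. Also open, on these data alone, is whether methyl and fluoro would read alike with the carboxy group placed as in compound 1.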